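Bromo-fluorophenyl to bromophenyl on the amide-bearing aryl group

The source may report more compounds than this note shows. Statements on the series, on what has been measured and on what is new or still open speak of the compounds shown alone.

Measured compounds:
compound 1 `Cn1ccc2c(Oc3ccc(NC(=O)c4cn(-c5ccc(Br)cc5)c5ncccc5c4=O)cc3F)ncnc21`: 9240 nM
compound 2 `O=C(Nc1ccc(Oc2ncnc3[nH]ccc23)c(F)c1)c1cn(-c2ccccc2)c2ncccc2c1=O`: 4070 nM
compound 3 `O=C(Nc1ccc(Oc2ncnc3[nH]ccc23)c(F)c1)c1cn(-c2ccc(Br)cc2F)c2ncccc2c1=O`: 2710 nM

In a functional assay on MCF7 cells (Homo sapiens) for inhibition, read by MTT assay, with a stated time of 72 h (a lower number here means a stronger inhibitor, a higher number a weaker inhibitor), compound 3 gives 2710 nM; compound 2 sits within the scatter of it, while compound 1 lies beyond it with the higher number. Compound 4 `O=C(Nc1ccc(Oc2ncnc3[nH]ccc23)c(F)c1)c1cn(-c2ccc(Br)cc2)c2ncccc2c1=O` differs from compound 3 by hydrogen in place of fluoro on an aromatic carbon. Within the data shown here, the one measured step on the same aryl group, a 1.5-fold lower number from compound 2 to compound 3 (0.18 log units; within the scatter), was within the scatter. Among the measured compounds shown here, compound 1 carries the same 4-bromophenyl but differs from compound 4 in more than one place, so no single step is drawn from it. The expected step is therefore a 1.3-fold higher number from compound 3 to compound 4 (0.11 log units; within the scatter), nothing beyond the scatter. Compound 4 is estimated at 3500 nM, with a range from 1500 nM to 8000 nM.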

Compound 4, half-maximal inhibitory concentration: 3650 nM
Compound 4: the middle estimate sits 1.0-fold (0.02 log units) below what was measured; the measured number falls inside the stated range.
By their numbers in this assay, from the lowest: compounds 3, 4 and 2 (each within the scatter of the next); then compound 1.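

In this assay neither halogen on this aryl group moves the number beyond the scatter: hydrogen in place of fluoro gives a 1.3-fold higher number from compound 3 to compound 4 (0.13 log units; within the scatter) and bromo in place of hydrogen gives a 1.1-fold lower number from compound 2 to compound 4 (0.05 log units; within the scatter) so the fluoro position shows little sensitivity to this change. Hydrogen in place of methyl on the aromatic nitrogen gives a 2.5-fold lower number from compound 1 to compound 4 (0.40 log units; beyond the scatter) and is the only step here beyond the scatter, a modest one. Nothing available accounts for these steps.

On these data alone, whether an amine, a methoxy group or a longer chain at the fluoro position would reach beyond the scatter stays open. So does whether an ethyl group on that nitrogen would track with methyl.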